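Aryl sulfone exchange: from compound 2 to compound 3

The source may hold more compounds than are shown below. What is called first, only, known or untested is meant among the compounds shown, and "the series" means these compounds.

In an assay for binding affinity to Neuropeptide Y receptor type 1 (Homo sapiens), read by radioligand binding (on this read-out higher numbers stand for weaker inhibition and lower numbers for stronger inhibition), two compounds of this small set have been run. Compound 1 `CNc1cc(S(=O)(=O)c2ccccc2)c([N+](=O)[O-])c2cccnc12` returns only a limit, > 10000 nM, which is the point described by the limit of > 10000 nM in this assay, at which 1 of the 2 values shown sits, and not a measured number. Among the measured compounds shown here, compound 2 `Nc1cc(S(=O)(=O)c2ccc(Cl)cc2)c([N+](=O)[O-])c2cccnc12` gives 1750 nM and is therefore the only compound of the set with a numerical inhibition constant. For the measured compounds named here, no pair of measured compounds differs in a single place, so no measured step is available for comparison.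

Compound 3 `CCc1ccccc1S(=O)(=O)c1cc(N)c2ncccc2c1[N+](=O)[O-]` is the next candidate for this assay. It differs from compound 2 by 2-ethylphenyl in place of 4-chlorophenyl on a sulfonyl sulfur. Going by the values given here, with no measured step in the set to lean on, the working expectation is a change that stays within the usual scatter, or at most a modest weakening. The expected step, a 1.4-fold higher number from compound 2 to compound 3 (0.15 log units; within the scatter), reflects that. Compound 3 is accordingly estimated at 2500 nM, with a range from 800 nM to 8000 nM.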

Compound 3, inhibition constant: 129 nM
Compound 3: the middle estimate sits 19-fold (1.29 log units) above what was measured, and the stated range ends above it.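

In this assay, the aryl group on a sulfonyl sulfur emerges as a place where one exchange can move the read-out well beyond the scatter: 2-ethylphenyl in place of 4-chlorophenyl gives a 14-fold lower number from compound 2 to compound 3 (1.13 log units; beyond the scatter) with the rest of the molecule unchanged. Among the compounds shown here, this is the first measured step in the set between compounds that differ in one place, and it makes compound 3, at 129 nM in this assay, the new reference point for further exchanges on the sulfonyl sulfur. Nothing among the data shown bears on why this exchange gives the lower number.

The exchange removes the chlorine and adds the ethyl group in a single step, so the compounds shown do not separate the contribution of losing one from that of gaining the other. Also open, as far as these compounds go, is how the read-out responds when a methyl group or a longer propyl chain replaces the ethyl group of compound 3, or when a methoxy group or a carboxylic acid is carried on that aromatic ring instead.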